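The source may report more compounds than this note shows. Statements on the series, on what has been measured and on what is new or still open speak of the compounds shown alone.

In a functional assay on HT-29 cells (Homo sapiens) for inhibition, read by MTT assay, with a stated time of 48 h (on this read-out higher numbers stand for weaker inhibition and lower numbers for stronger inhibition), compound 1 `COc1cc(-c2nnc(SCc3ccc(F)cc3)n2-c2ccc(N(C)C)cc2)cc(OC)c1OC` gives 44300 nM and compound 2 `COc1cc(-c2nnc(SCC(=O)c3ccccc3)n2-c2ccc(N(C)C)cc2)cc(OC)c1OC` gives 45200 nM while compound 3 `COc1ccc(C(=O)CSc2nnc(-c3cc(OC)c(OC)c(OC)c3)n2-c2ccc(N(C)C)cc2)cc1` gives 64000 nM and so cannot be told apart from either of them. Compound 4 `COc1cc(-c2nnc(SCC(=O)C3CC3)n2-c2ccc(N(C)C)cc2)cc(OC)c1OC` carries cyclopropyl in place of 4-methoxyphenyl on a carbonyl carbon. Among the measured compounds shown here, three measured steps bear on it, a 1.0-fold higher number from compound 1 to compound 2 (0.01 log units; within the scatter) together with a 1.4-fold higher number from compound 1 to compound 3 (0.16 log units; within the scatter) and a 1.4-fold higher number from compound 2 to compound 3 (0.15 log units; within the scatter) and all of them lie within the scatter. None of them places cyclopropyl on the carbonyl carbon, so the data give no direct measure of this change. Reasoning from the small size of a 1.4-fold higher number from compound 1 to compound 3 (0.16 log units; within the scatter) and the other two steps, no step beyond the scatter is expected in this assay here. The estimated step is a 1.3-fold lower number from compound 3 to compound 4 (0.11 log units; within the scatter) and it stays within the scatter. Compound 4 is estimated at 50000 nM (range 25000 nM to 100000 nM).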

Compound 4, half-maximal inhibitory concentration: > 60000 nM
Compound 4 gave a limit, no number (the forecaster's own chance of this, stated with the estimate: 10%); at least 1.2-fold (0.07 log units) between middle value and limit.
By their numbers in this assay, from the lowest: compounds 1, 2 and 3 (each within the scatter of the next).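

With cyclopropyl on the carbonyl carbon, a non-aromatic ring stands where compounds 2 and 3 carry an aromatic one, and in this assay compound 4 gives only a limit of the assay, not a number: the limit of > 60000 nM in this assay, at which 1 of the 4 values shown sits. The readable steps are an at least 1.3-fold higher number from compound 2 to compound 4 (0.12 log units; that floor lies within the scatter) and an at least 1.3-fold higher number from compound 1 to compound 4 (0.13 log units; that floor lies within the scatter), so this change gives no sign of stronger inhibition, though both floors stay within the scatter. The step from compound 3 cannot be read. The compounds shown leave open how an amine or a carboxylic acid on the carbonyl carbon would read in this assay.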